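Branched and linear chains on the ring nitrogen

The source may hold more compounds than are shown below. What is called first, only, known or untested is meant among the compounds shown, and "the series" means these compounds.

Measured compounds in an assay on Prostate gland for inhibition of steroid 5-alpha-reductase (Rattus norvegicus); a lower number here means a stronger inhibitor, a higher number a weaker inhibitor:
compound 1 `C/C(=C\C(=O)Nc1ccccc1OCCCC(=O)O)c1ccc2c(ccn2C)c1`, 780 nM
compound 2 `CCCCCCn1ccc2cc(/C(C)=C/C(=O)Nc3ccccc3OCCCC(=O)O)ccc21`, 77 nM
compound 3 `CCC(C)n1ccc2cc(/C(C)=C/C(=O)Nc3ccccc3OCCCC(=O)O)ccc21`, 67 nM

Compound 2 sits close to compound 3, the two numbers lying within the scatter of each other, as a 1.1-fold lower number from compound 2 to compound 3 (0.06 log units; within the scatter) shows. The distance to compound 1 is large and clearly beyond the scatter: a 10-fold lower number from compound 1 to compound 2 (1.01 log units; beyond the scatter). The same sort of gap separates compound 1 from compound 3, given by a 12-fold lower number from compound 1 to compound 3 (1.07 log units; beyond the scatter).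

Compound 4 `CCCC(C(C)C)n1ccc2cc(/C(C)=C/C(=O)Nc3ccccc3OCCCC(=O)O)ccc21` has not yet been measured in this assay. It differs from compound 2 in one place: 1-isopropylbutyl in place of hexyl on an aromatic nitrogen.

Two of the measured steps bear on this change. Going from hydrogen or methyl to a longer chain on that nitrogen lowered the number strongly in both cases, a 10-fold lower number from compound 1 to compound 2 (1.01 log units; beyond the scatter) and a 12-fold lower number from compound 1 to compound 3 (1.07 log units; beyond the scatter), but exchanging one larger chain for another, branched one made no difference beyond the scatter, a 1.1-fold lower number from compound 2 to compound 3 (0.06 log units; within the scatter). Compound 4 keeps a chain of comparable size, now branched. The step from compound 2 to compound 4 in this assay is therefore expected to be small, a 1.2-fold lower number from compound 2 to compound 4 (0.07 log units; within the scatter), with no change beyond the scatter. The estimate for compound 4 is 65 nM, in a range from 25 nM to 160 nM.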

Compound 4, half-maximal inhibitory concentration: 7.2 nM
The estimate for compound 4 lay 9.0-fold (0.96 log units) above the measured number; the measured number lies below the stated range.
By their numbers in this assay, from the lowest: compound 4; then compounds 3 and 2 (each within the scatter of the next); then compound 1.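

In this assay, the chain on the aromatic nitrogen seemed to have levelled off once it was larger than methyl, yet an 11-fold lower number from compound 2 to compound 4 (1.03 log units; beyond the scatter) and a 9.3-fold lower number from compound 3 to compound 4 (0.97 log units; beyond the scatter) show that this position still discriminates among larger chains. Branching alone does not account for this, since compound 3 is also branched and stays within the scatter of compound 2, so the gain can be tied only to 1-isopropylbutyl as a whole, with a 110-fold lower number from compound 1 to compound 4 (2.03 log units; beyond the scatter) as the full span seen at this position. Nothing at hand explains the gain.

As far as these compounds go, it remains open whether a longer branched chain, such as 1-propylpentyl, or a cyclohexyl ring on the same nitrogen would hold this level. Also open, from the compounds shown here alone, is whether an amine at the end of the chain would be tolerated.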